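Swapping a dichlorophenyl for a methylfuran on a weak inhibitor

A few compounds are considered here, and "the series" means these few. Any claim that something is new, unique, unknown or untested is made for them only; others in the source may bear on it.

Two compounds from this study share a common core carrying a cyano group and a methoxy group. Compound 1 `COc1nc(-c2nc3ccccc3[nH]2)cc(-c2ccc(Cl)cc2)c1C#N` and compound 2 `COc1nc(-c2nc3ccccc3n2C)cc(-c2ccc(Cl)cc2Cl)c1C#N` were both tested in a functional assay on aorta (Rattus norvegicus, strain Wister); a higher number here means a weaker inhibitor, a lower number a stronger inhibitor. In this assay compound 1 gives 286000 nM, and compound 2 gives 214000 nM. The two numbers lie within the scatter of each other, so on these data compound 2 and compound 1 are indistinguishable, and both are weak inhibitors.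

Compound 3 `COc1nc(-c2nc3ccccc3n2C)cc(-c2ccc(C)o2)c1C#N` has not been measured. It differs from compound 2 in one place: 5-methylfuran-2-yl in place of 2,4-dichlorophenyl on an aromatic carbon. Among the measured compounds shown here, no measured pair in this study shows what such a change does, so the expectation rests only on the two weak values seen so far. The step from compound 2 to compound 3 is expected to be a 1.4-fold higher number from compound 2 to compound 3 (0.15 log units; within the scatter), that is, no change beyond the scatter, with the value for compound 3 expected to remain in the weak range of compound 2 at 214000 nM. For compound 3 the estimate in this assay is 300000 nM, with a range from 100000 nM to 1000000 nM.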

Compound 3, half-maximal inhibitory concentration: 283000 nM
Compound 3: middle estimate off by 1.1-fold (0.03 log units), on the high side; the measured number falls inside the stated range.
By their numbers in this assay, from the lowest: compounds 2, 3 and 1 (each within the scatter of the next).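

Among the compounds shown here, replacing 2,4-dichlorophenyl with 5-methylfuran-2-yl gives a 1.3-fold higher number from compound 2 to compound 3 (0.12 log units; within the scatter) in this assay, the first direct reading of a single change at this position. On this shared core, at the aromatic carbon ortho to a cyano group and opposite the ring nitrogen, a six-membered carbon ring with two chlorine atoms and a five-membered ring with one oxygen therefore cannot be told apart, even though the incoming group has fewer heavy atoms and adds a hydrogen-bond acceptor, and both compounds remain weak inhibitors. No available evidence bears on why these two groups read alike.

Both groups at this position are aromatic rings attached directly to the core, so these compounds leave open what a basic amine, a carboxylic acid or a longer alkyl chain would do there. On these data alone, it also remains open whether any group at this position can bring the number clearly below the weak range shared by compound 2 and compound 3, since a single pair cannot show how far this position can respond.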